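The compounds below may be only part of what the source reports. "The series", "measured", "known", "first", "only" and "open" are said of these compounds alone.

Measured compounds
- compound 1, `CC(C)NC(=O)/C=C1\CCc2ccc(F)cc21`: > 100 mg/kg
- compound 2, `O=C(/C=C1\CCc2c(F)ccc(F)c21)NC1CC1`: 2 mg/kg

Within the data shown here, in a functional assay on the whole organism with Mus musculus as the target, in the rotarod test (a higher number here means that more compound is needed for the effect, a lower number that less compound is needed), compound 2 gives 2 mg/kg, and this is the only actual number in the set. For compound 1 the entry in this assay, > 100 mg/kg, is a limit of the assay and not a number (the limit of > 100 mg/kg in this assay, at which 1 of the 2 values shown sits). Among the measured compounds shown here, compound 2 therefore stands alone as the one compound with a measured dose, and there is no second number against which it can be ordered.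

Compound 3, `NC(=O)/C=C1\CCc2c(F)ccc(F)c21`, has not yet been run in this assay. It differs from compound 2 in one place:

hydrogen in place of cyclopropyl on an amide-type nitrogen

For the measured compounds named here, no step between two measured compounds of this kind exists in the set, so the size of the change cannot be read off from a measured pair and has to be estimated from the change itself. For compound 3 the expected direction in this assay is toward a higher dose, with an estimated step of a 5.0-fold higher number from compound 2 to compound 3 (0.70 log units; beyond the scatter). Compound 3 is estimated at 10 mg/kg, with a likely range from 2 mg/kg to 60 mg/kg.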

Compound 3, dose for half-maximal effect: 89 mg/kg
The estimate for compound 3 lay 8.9-fold (0.95 log units) below the measured number, outside the stated range (above it).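

In this assay this amide-type nitrogen now has its first measured pair: putting hydrogen in place of cyclopropyl gives a 45-fold higher number from compound 2 to compound 3 (1.65 log units; beyond the scatter) and this step lies beyond the scatter. The group on this nitrogen therefore matters strongly for the dose needed on the core of compound 2, and the cyclopropyl-bearing amide is clearly favoured over the amide carrying only hydrogen. Among these compounds, compound 3 still gives a real number rather than a limit, but the single pair shows only the size and direction of this change, and nothing in the data bears on why it acts this way.

Going by these compounds, it remains open whether the difference belongs to the cyclopropyl ring itself or would appear with any small carbon group on this nitrogen, a question that methyl, ethyl, isopropyl or cyclobutyl on the same core would help to settle. Also open, on these data alone, is how this nitrogen would respond to a longer chain, or to a chain ending in a hydroxyl group or an amine.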